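Series notes: chain amide in place of benzylamide

The source may hold more compounds than are shown below. What is called first, only, known or untested is meant among the compounds shown, and "the series" means these compounds.

Of the compounds shown here, three have been measured in an ADME assay on MRC5 cells (Homo sapiens) for inhibition, with a stated time of 72 h; a lower number here means that less compound is needed, a higher number that more compound is needed for the effect. Compound 1 `CO[C@H]1CC[C@H](NC(=O)c2n[nH]cc2NC(=O)c2ccc(OC(F)F)cc2)CC1` gives 2500 nM. Compound 2 `CO[C@H]1CC[C@H](NC(=O)c2n[nH]cc2NC(=O)c2ccccc2C(F)(F)F)CC1` gives 3300 nM in this assay. Compound 3 `COc1cccc(OC)c1C(=O)Nc1c[nH]nc1C(=O)NCc1ccccc1` gives 50000 nM, the highest of the three numbers and beyond the scatter from both others. Compound 4 `COCCNC(=O)c1n[nH]cc1NC(=O)c1c(OC)cccc1OC` is not yet measured. It differs from compound 3 in one place: methoxymethyl in place of phenyl on a saturated chain carbon bound to an amide-type nitrogen. Among the measured compounds shown here, no step of this kind exists among the measured compounds, so its size is open. A step of modest size in either direction, from compound 3 to compound 4, is expected, a 1.7-fold lower number from compound 3 to compound 4 (0.22 log units; within the scatter), without clear ground for a large shift. Compound 4 is estimated at 30000 nM in this assay, with a range from 8000 nM to 100000 nM.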

Compound 4, half-maximal effective concentration: > 50000 nM
Compound 4 was reported as a limit; the forecaster's own chance of this, stated with the estimate: 15%; at least 1.6-fold (0.22 log units) between middle value and limit.
By their numbers in this assay, from the lowest: compounds 1 and 2 (each within the scatter of the next); then compound 3.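

In this assay, benzyl to 2-methoxyethyl at this amide-type nitrogen gives a number no lower from compound 3 to compound 4 (the limit leaves the size open), so the size of this step cannot be read. Compound 4 gives > 50000 nM, which is a limit of the assay and not a number. Methoxymethyl in place of phenyl on this saturated chain carbon therefore brings no lower number, and the reading stops at the limit: the limit of > 50000 nM in this assay, at which 1 of the 4 values shown sits.

Going by these compounds, how far compound 4 lies from compound 3 stays open. Also open, on these data alone, is how an amine or a carboxylic acid in place of methoxymethyl would read on this chain carbon.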